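Chain shortening in a series of phenolic acid antagonists

The compounds below may be only part of what the source reports. "The series", "measured", "known", "first", "only" and "open" are said of these compounds alone.

Measured so far:
compound 1, `CCCc1c(OCCCCCCC(=O)O)ccc(C(C)=O)c1O`, 5.7
compound 2, `CCCc1c(OCCCCCC(=O)O)ccc(C(C)=O)c1O`, 6

Both numbers come from a functional assay on ileum (Cavia porcellus) for inhibition of cysteinyl leukotriene receptor (Homo sapiens); on this read-out higher numbers stand for higher potency (the scale is a negative logarithm) and lower numbers for lower potency. Among the compounds with values here, of the two, the one for compound 2 stands at the top, but only by a number 0.30 log units higher from compound 1 to compound 2 (within the scatter), so the two compounds cannot be separated on this read-out.

Compound 3, `CCCc1c(OCCCCC(=O)O)ccc(C(C)=O)c1O`, is not yet measured. It differs from compound 2 as follows: carboxy in place of carboxymethyl on a saturated chain carbon, four bonds along the chain from an oxygen on an aromatic ring. Within the data shown here, the only measured step that bears on this change is the same difference cut one bond further out, from compound 1 to compound 2, which gave a number 0.30 log units higher from compound 1 to compound 2 (within the scatter). One step is a thin basis, and it lay within the scatter, so the expectation for compound 3 is a number close to that of compound 2, with no change beyond the scatter in either direction. The step from compound 2 to compound 3 is therefore estimated at a number 0.10 log units higher from compound 2 to compound 3 (within the scatter). For compound 3 in this assay the estimate is 6.1, with a range from 5.6 to 6.6.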

Compound 3, negative logarithm of the antagonist equilibrium constant: 5.8
For compound 3 the middle estimate is 0.30 log units above the measured one; measured number inside the range.
By their numbers in this assay, from the lowest: compounds 1, 3 and 2 (each within the scatter of the next).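

In this assay, carboxy in place of carboxymethyl on a saturated chain carbon, four bonds along the chain from an oxygen on an aromatic ring, gives a number 0.20 log units lower from compound 2 to compound 3 (within the scatter) and so, like the cut one bond further out, does not separate the two compounds. Over both cuts together, carboxy in place of 2-carboxyethyl at this same place gives a number 0.10 log units higher from compound 1 to compound 3 (within the scatter), so all three chain lengths lie within the scatter of one another on this read-out and no best length can be picked out from them. Nothing measured on these compounds offers an account of this flat response to chain length.

On these data alone, it remains open whether the flat stretch continues with still shorter chains, such as 3-carboxypropyl or 2-carboxyethyl on the oxygen, or whether a clear drop appears at some shorter length. Also open, as far as these compounds go, is whether the carboxylic acid at the chain end can give way to another group, such as a tetrazole or a primary amide, given that all three compounds carry the acid on the same shared core.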